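The source may hold more compounds than are shown below. What is called first, only, known or untested is meant among the compounds shown, and "the series" means these compounds.

The study turns on an assay for binding affinity to 17-beta-hydroxysteroid dehydrogenase type 1 (Homo sapiens), with a stated time of 20 min, tested at 1 uM; a lower number here means less inhibition, a higher number more inhibition at the concentration tested (going by the name of the read-out). Compound 1 `Oc1cccc2cc(-c3ccc(F)cc3)ccc12` sits at a limit of the assay: in this assay compound 1 gives < 10%, which is a limit rather than a number. Compound 2 `Oc1cccc2cc(-c3cncnc3)ccc12` likewise returns only a limit, giving < 10% in this assay. So (the limit of < 10% in this assay, at which 2 of the 2 values shown sit), and nothing more precise is known about where compound 1 stands. Compound 3 `CNC(=O)c1ccc(-c2ccc3c(O)cccc3c2)cc1` has not yet been measured. It differs from compound 1 in one change: methylcarbamoyl in place of fluoro on an aromatic carbon. Going by the values given here, no step between measured compounds is available, so the size of this change cannot be read from the data and can only be expected. A modest rise is expected, with an expected step of a number at least 10 percentage points higher from compound 1 to compound 3 (that floor lies within the scatter), although a result that again stops at the limit remains quite possible. Compound 3 is therefore estimated at 20%, within a range from 0% to 55%.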

Compound 3, a percentage reported as inhibition, at one concentration (the size of the read-out at that concentration, not a potency): < 10%
Compound 3 was reported as a limit; the forecaster's own chance of this, stated with the estimate: 45%; middle value at least 10 percentage points from the limit.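

In this assay, going by these compounds alone, compound 1 and compound 3 both stop at a limit, so no step between them can be read: the limit of < 10% in this assay, at which 3 of the 3 values shown sit. The compounds shown leave open whether methylcarbamoyl in place of fluoro changes inhibition at all, and how far each compound lies under that limit.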